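Fluorine on the Indole Ring: A Small Step Expected

The source may report more compounds than this note shows. Statements on the series, on what has been measured and on what is new or still open speak of the compounds shown alone.

Compound 1, `COc1cc(N(C)CCN(C)C)c(NC(=O)/C=C\C(C)C)cc1Nc1ncc(C#N)c(-c2cn(C)c3ccccc23)n1`: 1100 nM
Compound 2, `CCC/C=C\C(=O)Nc1cc(Nc2ncc(C#N)c(-c3cn(C)c4ccccc34)n2)c(OC)cc1N(C)CCN(C)C`: 166 nM

Both compounds were tested in a functional assay on A549 cells (Homo sapiens) for antiproliferative activity, read by MTT assay, with a stated time of 72 h; a higher number here means a weaker inhibitor, a lower number a stronger inhibitor. Compound 1 gives the highest number of the pair; its nearest neighbour is compound 2, reached by a 6.6-fold lower number from compound 1 to compound 2 (0.82 log units; beyond the scatter), a change on the amide-bearing chain and not on the ring system.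

Compound 3, `COc1cc(N(C)CCN(C)C)c(NC(=O)/C=C\C(C)C)cc1Nc1ncc(C#N)c(-c2cn(C)c3ccc(F)cc23)n1`, has not yet been measured. It differs from compound 1 by fluoro in place of hydrogen on an aromatic carbon. Among the compounds with values here, no measured step touches this part of the molecule: the only step known, from compound 1 to compound 2, alters a distant chain and so says nothing about what a fluoro group on the indole will do. The expectation therefore rests on the value of compound 1 alone, and a step of a 1.4-fold lower number from compound 1 to compound 3 (0.14 log units; within the scatter) is expected, within the scatter. Compound 3 is estimated at 800 nM, with a range from 300 nM to 2500 nM.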

Compound 3, half-maximal inhibitory concentration: 185 nM
For compound 3 the middle estimate is 4.3-fold (0.64 log units) above the measured one, and the stated range ends above it.
By their numbers in this assay, from the lowest: compounds 2 and 3 (each within the scatter of the next); then compound 1.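

In this assay, a single fluoro on the six-membered aromatic ring of the 1-methyl-1H-indol-3-yl group moves the result beyond the scatter, with a 5.9-fold lower number from compound 1 to compound 3 (0.77 log units; beyond the scatter). Within the data shown here, this aromatic carbon, which the earlier compounds left unchanged, is therefore not a silent position: replacing hydrogen with one heavy atom here shifts the result towards a stronger inhibitor. Nothing available explains why this change has this effect.

The compounds shown leave open whether another group on this same carbon, such as chloro, methoxy or an amine, would give a similar step. Also open, as far as these compounds go, is whether the same fluoro group would produce a step of similar size on compound 2, which carries the propyl chain.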